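A few compounds are considered here, and "the series" means these few. Any claim that something is new, unique, unknown or untested is made for them only; others in the source may bear on it.

Compound 1 `CCN(CC)CCCNC(=O)c1ccc(C(CC)(CC)c2ccc(OCC(=O)C(C)(C)C)c(C)c2)n1CC` is the reference here. In a functional assay on MCF7 cells (Homo sapiens), read by MTT assay, with a stated time of 48 h (on this read-out lower numbers stand for stronger inhibition and higher numbers for weaker inhibition), compound 1 gives 530 nM. Compound 2 `CCN(CC)CCCNC(=O)c1ccc(C(CC)(CC)c2ccc(OCC(O)C(C)(C)C)c(C)c2)n1CC` differs from it by 1-hydroxy-2,2-dimethylpropyl in place of (tert-butyl)carbonyl on a saturated chain carbon bound to an oxygen on an aromatic ring; in this assay compound 2 gives 190 nM, a 2.8-fold lower number from compound 1 to compound 2 (0.45 log units; beyond the scatter). Compound 3 `CC[C@@H](C)[C@H](NC(=O)c1ccc(C(CC)(CC)c2ccc(OCC(=O)C(C)(C)C)c(C)c2)n1CC)C(=O)O` carries a different core, the difference being (1-carboxy-2-methylbutyl in place of 3-(diethylamino)propyl on an amide-type nitrogen); in this assay compound 3 gives 160 nM, a 3.3-fold lower number from compound 1 to compound 3 (0.52 log units; beyond the scatter). Compound 4 `CC[C@@H](C)[C@H](NC(=O)c1ccc(C(CC)(CC)c2ccc(OCC(O)C(C)(C)C)c(C)c2)n1CC)C(=O)O` has not been measured. It differs from compound 3 by 1-hydroxy-2,2-dimethylpropyl in place of (tert-butyl)carbonyl on a saturated chain carbon bound to an oxygen on an aromatic ring, the same change that separates compound 1 from compound 2, made at the same place. For compound 4 the expected step is a 2.3-fold lower number from compound 3 to compound 4 (0.36 log units; beyond the scatter). That expectation rests on the single earlier observation a 2.8-fold lower number from compound 1 to compound 2 (0.45 log units; beyond the scatter), scaled back a little since it was seen only once. In this assay compound 4 is estimated at 70 nM, with a likely range from 30 nM to 170 nM.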

Compound 4, half-maximal inhibitory concentration: 2000 nM
Compound 4: middle estimate off by 29-fold (1.46 log units), on the low side; measured number above the stated range.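

In this assay, putting 1-hydroxy-2,2-dimethylpropyl in place of (tert-butyl)carbonyl lowered the number on the core of compound 1 but raised it on the core of compound 3, with a 13-fold higher number from compound 3 to compound 4 (1.10 log units; beyond the scatter), so the change did not carry over from one core to the other: the same change on two cores in this assay, a 2.8-fold lower number (0.45 log units; beyond the scatter) from compound 1 to compound 2 and a 13-fold higher number (1.10 log units; beyond the scatter) from compound 3 to compound 4, 35-fold (1.54 log units) apart, beyond the scatter of two such steps

Seen from the other side, putting 1-carboxy-2-methylbutyl in place of 3-(diethylamino)propyl on the amide-type nitrogen also gave a different result once the hydroxy group was present, with an 11-fold higher number from compound 2 to compound 4 (1.02 log units; beyond the scatter): the same change on two cores in this assay, a 3.3-fold lower number (0.52 log units; beyond the scatter) from compound 1 to compound 3 and an 11-fold higher number (1.02 log units; beyond the scatter) from compound 2 to compound 4, 35-fold (1.54 log units) apart, beyond the scatter of two such steps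

So the two changes do not simply add up in these four compounds, but this does not show why, and one pair per core says nothing about other cores.

As far as these compounds go, it remains open whether the reversal goes with the carboxylic acid or with the branched chain carrying it. A methyl ester in place of the acid, or a plain carboxymethyl group on that nitrogen, would help separate the two.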